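The compounds below may be only part of what the source reports. "The series", "measured", "known", "first", "only" and "open" are said of these compounds alone.

Compound 1, `CN1CCN(c2ccc(Nc3ncc4nc(Nc5ccc(F)cc5)n([C@@H]5CCN(C(=O)CO)C5)c4n3)cc2)CC1`, gives 350 nM in a functional assay on HCC827 cells (Homo sapiens) for antiproliferative activity, read by MTT assay, with a stated time of 72 h; a higher number here means a weaker inhibitor, a lower number a stronger inhibitor.
Compound 2, `CN1CCN(c2ccc(Nc3ncc4nc(Nc5ccc(F)cc5)n([C@@H]5CCCNC5)c4n3)cc2)CC1`, gives 120 nM in this assay.
Compound 3, `CN1CCN(c2ccc(Nc3ncc4nc(Nc5ccc(F)cc5)n([C@@H]5CCNC5)c4n3)cc2)CC1`, gives 300 nM in this assay.

Compound 3 stands second highest of the three numbers; compound 1 sits nearest to it, and the step from compound 1 to compound 3 was a 1.2-fold lower number from compound 1 to compound 3 (0.07 log units; within the scatter), while the step from compound 2 to compound 3 was a 2.5-fold higher number from compound 2 to compound 3 (0.40 log units; beyond the scatter). The new compound 4, `CN1CCN(c2ccc(Nc3ncc4nc(Nc5ccc(F)cc5)n([C@H]5CCN(C(=O)CO)C5)c4n3)cc2)CC1`, differs from compound 3 by 1-((hydroxymethyl)carbonyl)pyrrolidin-3-yl in place of pyrrolidin-3-yl on an aromatic nitrogen. Within the data shown here, the measured step that bears most directly on this change is the reverse of the one from compound 1 to compound 3, which was a 1.2-fold lower number from compound 1 to compound 3 (0.07 log units; within the scatter). Compound 1 carries the same group as compound 4 but with the other defined stereocentre, so the transfer is not exact. The steps of a 2.9-fold lower number from compound 1 to compound 2 (0.46 log units; beyond the scatter) and a 2.5-fold higher number from compound 2 to compound 3 (0.40 log units; beyond the scatter) concern the ring size rather than the acyl group. The expectation for compound 4 is therefore a step of a 1.3-fold higher number from compound 3 to compound 4 (0.10 log units; within the scatter) in this assay, not clearly beyond the scatter. Compound 4 is estimated at 380 nM, within 150 nM to 900 nM.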

Compound 4, half-maximal inhibitory concentration: 380 nM
The estimate for compound 4 equals the measured number at the digits printed, within the range that was stated.
By their numbers in this assay, from the lowest: compound 2; then compounds 3, 1 and 4 (each within the scatter of the next).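

The step of a 1.1-fold higher number from compound 1 to compound 4 (0.04 log units; within the scatter) isolates the configuration at this saturated ring carbon, and it does not separate the two forms, a comparison that rests on one fact: the fact that compounds 1 and 4 differ only in the configuration as drawn. The step of a 1.3-fold higher number from compound 3 to compound 4 (0.10 log units; within the scatter) likewise brings in the 1-((hydroxymethyl)carbonyl)pyrrolidin-3-yl group with no change beyond the scatter. Only the piperidin-3-yl group still stands apart, as the step of a 3.2-fold higher number from compound 2 to compound 4 (0.50 log units; beyond the scatter) lies beyond the scatter in this assay and so extends that separation to the newly drawn configuration.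

The compounds shown leave open whether configuration counts for the pyrrolidin-3-yl and piperidin-3-yl groups, each of which appears here in one configuration only. Also open, on these data alone, is how an acetyl group, an aminoacetyl group or a carboxylic acid on the pyrrolidine nitrogen would read, or a (hydroxymethyl)carbonyl group on the piperidine nitrogen.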